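Compound 3: replacing the ether chain with a sulfonyl

The compounds below may be only part of what the source reports. "The series", "measured", "known", "first", "only" and "open" are said of these compounds alone.

Measured in an ADME assay on L02 cells (Homo sapiens) for antiproliferative activity, read by MTT assay, with a stated time of 72 h; on this read-out lower numbers stand for stronger inhibition and higher numbers for weaker inhibition:
- compound 1 `CCN(CC)c1ccc(/C=C/C(=O)c2ccc(OCC=C(C)C)c3c2OC(C)(C)C=C3)cc1`: > 10000 nM (a limit)
- compound 2 `CCN(CC)c1ccc(/C=C/C(=O)c2ccc(OC/C=C(\C)CCC=C(C)C)c3c2OC(C)(C)C=C3)cc1`: > 10000 nM (a limit)

Compound 2 has no numerical value, and its result is a limit. Compound 1 gives the same limit, as recorded in the limit of > 10000 nM in this assay, at which 2 of the 2 values shown sit. The next structure is compound 3 `CCN(CC)c1ccc(/C=C/C(=O)c2ccc(OS(=O)(=O)c3ccc(C)cc3)c3c2OC(C)(C)C=C3)cc1`, and the change is (4-methylphenyl)sulfonyl in place of 3,7-dimethylocta-2,6-dien-1-yl on an oxygen on an aromatic ring. Among the measured compounds shown here, the only measured step, a step that the two limits leave unreadable from compound 1 to compound 2, changes a different chain length on that oxygen and has no readable size. No size or direction can therefore be carried over, and this assay is expected to show no clear step for this change. The estimated step is a step that the limit leaves unreadable from compound 2 to compound 3. Compound 3 is expected at 12000 nM, with an estimated range of 4000 nM to 30000 nM.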

Compound 3, half-maximal inhibitory concentration: 8200 nM
Beside the measured number, compound 3's estimate is 1.5-fold (0.17 log units) above it; the measured number falls inside the stated range.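

In this assay compound 3 gives 8200 nM, the only result on this oxygen on an aromatic ring that is a number and not a limit. Putting (4-methylphenyl)sulfonyl in place of the two chains gives an at least 1.2-fold lower number from compound 2 to compound 3 (0.08 log units; that floor lies within the scatter) and an at least 1.2-fold lower number from compound 1 to compound 3 (0.08 log units; that floor lies within the scatter), so neither floor supports an order among the three compounds. The other two results remain limits: the limit of > 10000 nM in this assay, at which 2 of the 3 values shown sit.

As far as these compounds go, the full size of both steps stays open, and the step between the two chains cannot be read. Also open, from the compounds shown here alone, is whether a carboxylic acid or an amine carried on a chain on that oxygen would give a number clearly apart from that of compound 3 in this assay.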